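Naphthalenyl replaces formylphenyl on a shared imidazopyrazine-type core

The source may hold more compounds than are shown below. What is called first, only, known or untested is meant among the compounds shown, and "the series" means these compounds.

Measured compounds:
Compound 1, `c1ccc(-c2cn3ccnc3c(-c3ccc4ncn(C5CCCCC5)c4c3)n2)cc1`: 50.5%
Compound 2, `O=Cc1ccc(-c2cn3ccnc3c(-c3ccc4ncn(C5CCCCC5)c4c3)n2)cc1`: 37.4%

In a functional assay on NCI/ADR-RES cells (Homo sapiens) for inhibition, read by sulforhodamine B assay, with a stated time of 48 h, tested at 10 uM (on this read-out higher numbers stand for more inhibition at the one concentration tested (going by the name of the read-out) and lower numbers for less inhibition), compound 1 gives 50.5%. In this assay compound 2 gives 37.4%, the lowest of the two numbers, and the step of a number 13.1 percentage points lower from compound 1 to compound 2 (beyond the scatter) shows a modest fall with the addition of a formyl group.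

Compound 3, `c1ccc2c(-c3cn4ccnc4c(-c4ccc5ncn(C6CCCCC6)c5c4)n3)cccc2c1`, has not yet been measured in this assay. Its change from compound 2 is naphthalen-1-yl in place of 4-formylphenyl on an aromatic carbon. For the measured compounds named here, the only measured step that bears on it is a number 13.1 percentage points lower from compound 1 to compound 2 (beyond the scatter), which describes the loss of the formyl; compound 3 removes it again, so that part of the change is expected to undo the fall. Going by the values given here, for the added fused ring of naphthalen-1-yl no step is known, so the expectation is wide. The expected step is a number 10.6 percentage points higher from compound 2 to compound 3 (beyond the scatter), a modest rise. Compound 3 is therefore estimated at 48%, between 30% and 65%.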

Compound 3, a percentage reported as inhibition, at one concentration (the size of the read-out at that concentration, not a potency): 4.43%
Beside the measured number, compound 3's estimate is 43.6 percentage points above it, outside the stated range (below it).
By their numbers in this assay, from the lowest: compound 3; then compound 2; then compound 1.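

Until now only a substituent on the phenyl ring had changed, and compound 3 shows that in this assay replacing that ring at this aromatic carbon can cost much more. Naphthalen-1-yl in place of phenyl gives a large fall (a number 46.1 percentage points lower from compound 1 to compound 3 (beyond the scatter)), and naphthalen-1-yl in place of 4-formylphenyl also gives a large fall (a number 33 percentage points lower from compound 2 to compound 3 (beyond the scatter)), so the absence of the formyl does not by itself restore the level of compound 1, and this position does not accept the second fused aromatic ring without loss. Nothing available explains this fall. 

The compounds shown leave open whether the loss follows the fused ring itself or its point of attachment, as naphthalen-2-yl would test. They also leave open how a phenyl ring carrying an amine or a carboxylic acid in place of the formyl would read out here.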